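The source may report more compounds than this note shows. Statements on the series, on what has been measured and on what is new or still open speak of the compounds shown alone.

Working notes on the series. Compound 1 `COc1ccccc1OC[C@@H]1CCc2cc([C@H]3CC[C@](N)(CO)C3)ccc2C1` and compound 2 `COc1ccc(OC[C@@H]2CCc3cc([C@H]4CC[C@](N)(CO)C4)ccc3C2)cc1C(C)(C)C` share one core and differ in the aryl ether. For the measured compounds named here, in a functional assay on the whole organism (strain Lewis) with Rattus norvegicus as the target, with a stated time of 24 h, at a dose of 2 mg/kg by the oral route (on this read-out lower numbers stand for less inhibition and higher numbers for more inhibition at the one dose given (going by the name of the read-out)), compound 1 gives 85%, the highest of the two numbers recorded; compound 2 gives 53% in this assay, a gap beyond the scatter, though no single-change step links the pair. Compound 3 `N[C@]1(CO)CC[C@H](c2ccc3c(c2)CC[C@@H](COc2ccc(F)cc2)C3)C1` is compound 1 with 4-fluorophenyl in place of 2-methoxyphenyl on an oxygen on a saturated carbon. Going by the values given here, no measured pair carries this change. A modest loss is expected, with the step of a number 13 percentage points lower from compound 1 to compound 3 (beyond the scatter) estimated to sit at the edge of the scatter. Compound 3 is estimated at 72%, range 45% to 92%.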

Compound 3, a percentage reported as inhibition, in the whole organism at one dose (the size of the read-out at that dose, not a potency): 74%
Beside the measured number, compound 3's estimate is 2 percentage points below it; the range from low to high includes it.
By their numbers in this assay, from the lowest: compound 2; then compound 3; then compound 1.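

For the compounds shown here, the only single-change step at this position is 4-fluorophenyl in place of 2-methoxyphenyl on an oxygen on a saturated carbon, and in this assay it gives a number 11 percentage points lower from compound 1 to compound 3 (beyond the scatter). The aryl group can therefore be changed with a modest loss, and compound 3 keeps 74%. Nothing available accounts for the size of this step.

The change alters both the substituent and its ring position, so the two remain unseparated. An unsubstituted phenyl, a 2-fluorophenyl or a 4-methoxyphenyl on the same oxygen would pull them apart.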